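This account rests on a few compounds, and the source may have more. Where it says the series, first, only, none or still open, it means among the compounds named here.

Measured in a functional assay on Huh-7 cells (Homo sapiens) for inhibition, read by MTT assay, with a stated time of 48 h; on this read-out lower numbers stand for stronger inhibition and higher numbers for weaker inhibition:
Compound 1 `COc1ccc2c(=O)c(/C=C/C(=O)Nc3cccc(Cl)c3)coc2c1`: > 100000 nM (a limit of the assay, not a number)
Compound 2 `COc1ccc2c(=O)c(/C=C/C(=O)Nc3ccccc3)coc2c1`: 9050 nM
Compound 3 `COc1cccc(NC(=O)/C=C/c2coc3cc(OC)ccc3c2=O)c1`: 11100 nM

Among the compounds with values here, compound 3, at 11100 nM, stands within the scatter of compound 2, the only other compound with a true number. Compound 4 `COc1ccc2c(=O)c(/C=C/C(=O)NCc3cccc(F)c3)coc2c1` has not yet been measured. Its change from compound 3 is 3-fluorobenzyl in place of 3-methoxyphenyl on an amide-type nitrogen.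

Within the data shown here, no measured step makes this exchange, since all three only swap one group on an aromatic carbon. Two kinds of evidence bear on it indirectly. Methoxy in place of hydrogen made no real difference, as a 1.2-fold higher number from compound 2 to compound 3 (0.09 log units; within the scatter) shows. Replacing chloro had a far larger effect, with an at least 11-fold lower number from compound 1 to compound 2 (1.04 log units; beyond the scatter) and an at least 9.0-fold lower number from compound 1 to compound 3 (0.95 log units; beyond the scatter). From the compounds shown here alone, compound 4 also carries a halogen, so an at least 11-fold lower number from compound 1 to compound 2 (1.04 log units; beyond the scatter) argues for caution, although fluoro itself is untested.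

No step beyond the scatter is expected, with a slight lean towards a higher number, and the estimated step is a 1.4-fold higher number from compound 3 to compound 4 (0.16 log units; within the scatter). For compound 4 the estimated value is 16000 nM, with an expected range of 5000 nM to 60000 nM.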

Compound 4, half-maximal inhibitory concentration: 10100 nM
Estimate against measurement, compound 4: 1.6-fold (0.20 log units) above, and the stated range covers the measured number.
By their numbers in this assay, from the lowest: compounds 2, 4 and 3 (each within the scatter of the next). At a limit, above all of these: compound 1.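

In this assay, the amide-type nitrogen accepts a change of its whole group, not just of one ring substituent: 3-fluorobenzyl for 3-methoxyphenyl gives a 1.1-fold lower number from compound 3 to compound 4 (0.04 log units; within the scatter), and 3-fluorobenzyl for phenyl gives a 1.1-fold higher number from compound 2 to compound 4 (0.05 log units; within the scatter). Within the data shown here, the earlier steps changed only one group on an aromatic carbon, and they left unclear whether any halogen in this part of the molecule would go with a value at the limit, yet compound 4 carries fluoro and has a true number. The exchange of 3-chlorophenyl for 3-fluorobenzyl gives an at least 9.9-fold lower number from compound 1 to compound 4 (0.99 log units; beyond the scatter), and its size rests on a limit, not a number: the limit of > 100000 nM in this assay, at which 1 of the 4 values shown sits.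

From the compounds shown here alone, it remains open whether the fluoro and the benzyl carbon each matter on their own, which a plain benzyl or a 3-fluorophenyl on the amide-type nitrogen would separate. Going by these compounds, how an amine or a carboxylic acid on that ring would read in this assay is also open.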